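The compounds below may be only part of what the source reports. "The series", "measured", "known", "first", "only" and "open" are said of these compounds alone.

Measured so far:
- compound 1 `CC(=O)c1ccc(NC(=O)C(=O)NC(c2nc(C)c(CO)s2)C2CCCCN2)cc1`: > 107000 nM (a limit)
- compound 2 `Cc1nc(C(NC(=O)C(=O)Nc2ccc(F)c(Cl)c2)C2CCCCN2)sc1CCO`: 94700 nM

Among the measured compounds shown here, in an ADME assay on MT2 cells (Homo sapiens) for cytotoxicity, read by XTT assay, with a stated time of 4 days (a higher number here means that more compound is tolerated, a lower number that less compound is tolerated), compound 2 gives 94700 nM, the only exact number so far. Compound 1, which also carries 4-acetylphenyl, stands at a limit, > 107000 nM.

Compound 3 `CC(=O)c1ccc(NC(=O)C(=O)NC(c2nc(C)c(CCO)s2)C2CCCCN2)cc1` has 4-acetylphenyl in place of 3-chloro-4-fluorophenyl on an amide-type nitrogen. For the measured compounds named here, no measured step shows this change directly. In this assay, a 1.1-fold higher number from compound 2 to compound 3 (0.04 log units; within the scatter) is expected to stay within the usual scatter, slightly upward if anything. For compound 3 the estimated value is 105000 nM, with an expected range of 60000 nM to 160000 nM.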

Compound 3, half-maximal cytotoxic concentration: > 48300 nM
Compound 3 gave a limit, no number; the forecaster's own chance of this, stated with the estimate: 60%; the middle value is on the limit's open side.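

Compound 3 gives only a limit, so its steps from compound 2 and from compound 1 cannot be read. Still open, on these data alone, is whether 4-acetylphenyl in place of 3-chloro-4-fluorophenyl, or the hydroxymethyl change between compound 1 and compound 3, shifts the tolerated concentration at all.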